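From phenethyl to 3-methoxyphenyl on a carbonyl carbon

The compounds below may be only part of what the source reports. "The series", "measured", "known", "first", "only" and "open" are said of these compounds alone.

- compound 1 `CC(=O)N(C)c1ccc2[nH]c(-c3n[nH]c4ccccc34)cc2n1` gives 5110 nM
- compound 2 `CN(C(=O)CCc1ccccc1)c1ccc2[nH]c(-c3n[nH]c4ccccc34)cc2n1` gives 4730 nM

Among the measured compounds shown here, both values come from a functional assay on HL-60 cells (Homo sapiens) for antiproliferative activity, read by MTT assay, with a stated time of 72 h (on this read-out higher numbers stand for weaker inhibition and lower numbers for stronger inhibition), and the only measured step is a 1.1-fold lower number from compound 1 to compound 2 (0.03 log units; within the scatter) with benzyl in place of hydrogen on a saturated chain carbon bound to a carbonyl carbon. Compound 2 therefore stands level with compound 1, and the two cannot be ranked.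

Compound 3 `COc1cccc(C(=O)N(C)c2ccc3[nH]c(-c4n[nH]c5ccccc45)cc3n2)c1` is still unmeasured. Its change from compound 2 reads 3-methoxyphenyl in place of phenethyl on a carbonyl carbon and puts 3-methoxyphenyl in place of phenethyl on a carbonyl carbon. For the measured compounds named here, no measured compound carries 3-methoxyphenyl, so that single step is a thin guide. Its small size gives no reason to expect a shift in either direction beyond the scatter in this assay for this change. The expected step is a 1.1-fold lower number from compound 2 to compound 3 (0.02 log units; within the scatter) as an estimate. For compound 3 the estimated value is 4500 nM with an expected range from 1800 nM to 10000 nM in this estimate.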

Compound 3, half-maximal inhibitory concentration: 1420 nM
Beside the measured number, compound 3's estimate is 3.2-fold (0.50 log units) above it; the measured number lies below the stated range.
By their numbers in this assay, from the lowest: compound 3; then compounds 2 and 1 (each within the scatter of the next).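

In this assay, among the compounds shown here, the group on this carbonyl carbon now proves able to move the number: putting 3-methoxyphenyl in place of phenethyl gives a 3.3-fold lower number from compound 2 to compound 3 (0.52 log units; beyond the scatter) and is the first step here beyond the scatter. Putting 3-methoxyphenyl in place of methyl gives a 3.6-fold lower number from compound 1 to compound 3 (0.56 log units; beyond the scatter), so compound 3 stands apart from two compounds that could not be ranked against each other. Phenethyl and 3-methoxyphenyl have the same heavy-atom count and each holds one six-membered aromatic ring, so those counts do not separate them, and no separate measurement accounts for the step.

The change removes the saturated chain and adds the methoxy group together, so the compounds shown cannot tell which of the two matters. From the compounds shown here alone, a plain phenyl on this carbonyl carbon would separate them, and how a ring bearing an amine or a carboxylic acid would behave also remains open.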